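The compounds below may be only part of what the source reports. "The series", "measured", "known", "first", "only" and "open" are said of these compounds alone.

Measured compounds:
Compound 1, `COc1cccc(C(=O)Oc2ccc3c(=O)c(-c4cc(OC)c(OC)cc4OC)coc3c2)c1`. In a functional assay on A-375 cells (Homo sapiens) for antiproliferative activity, read by MTT assay, with a stated time of 24 h (a lower number here means a stronger inhibitor, a higher number a weaker inhibitor), compound 1 gives > 10000 nM, which is a limit of the assay.
Compound 2, `COc1cc(OC)c(-c2coc3cc(OCc4ccc([N+](=O)[O-])cc4)ccc3c2=O)cc1OC`. In this assay compound 2 gives > 10000 nM, also a limit.
Compound 3, `COc1cc(OC)c(-c2coc3cc(OCc4ccccc4C#N)ccc3c2=O)cc1OC`. In this assay compound 3 gives 990 nM.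

Compound 1 therefore stands at the limit of > 10000 nM in this assay, at which 2 of the 3 values shown sit, with no number of its own. Compound 4, `COc1cc(OC)c(-c2coc3cc(OCc4ccc(Cl)cc4)ccc3c2=O)cc1OC`, differs from it by 4-chlorobenzyl in place of (3-methoxyphenyl)carbonyl on an oxygen on an aromatic ring. The measured steps at this oxygen read a step that the two limits leave unreadable from compound 1 to compound 2 and an at least 10-fold lower number from compound 1 to compound 3 (1.00 log units; beyond the scatter); between the two benzyl ethers, an at least 10-fold lower number from compound 2 to compound 3 (1.00 log units; beyond the scatter). The 4-chlorobenzyl of compound 4 is named like the 4-nitrobenzyl of compound 2, which stays at the limit, while only the 2-cyanobenzyl of compound 3 yields a number. A step of an at least 2.0-fold lower number from compound 1 to compound 4 (0.30 log units; that floor lies within the scatter) is expected, with a real chance of another limit. Compound 4 is estimated at 5000 nM, between 1500 nM and 20000 nM.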

Compound 4, half-maximal inhibitory concentration: 1020 nM
Estimate against measurement, compound 4: 4.9-fold (0.69 log units) above; the measured number lies below the stated range.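

In this assay, 4-chlorobenzyl in place of (3-methoxyphenyl)carbonyl gives an at least 9.8-fold lower number from compound 1 to compound 4 (0.99 log units; beyond the scatter), so a readable number on this oxygen no longer rests on the 2-cyanobenzyl group alone. Among the benzyl ethers, 4-chlorophenyl in place of 2-cyanophenyl gives a 1.0-fold higher number from compound 3 to compound 4 (0.01 log units; within the scatter), while chloro in place of nitro gives an at least 9.8-fold lower number from compound 2 to compound 4 (0.99 log units; beyond the scatter). Compound 2, a benzyl ether at a limit of the assay, goes against any rule that benzyl ethers as a class give a number: the limit of > 10000 nM in this assay, at which 2 of the 4 values shown sit.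

From the compounds shown here alone, how an unsubstituted benzyl or a phenylethyl group would read on this oxygen remains open. So does the outcome for a carboxylic acid or an amine on the benzyl ring.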